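A few compounds are considered here, and "the series" means these few. Any claim that something is new, unique, unknown or untested is made for them only; others in the source may bear on it.

Working notes on the series. In a functional assay on MCF7 cells (Homo sapiens) for cytotoxicity, read by MTT assay, with a stated time of 24 h (on this read-out higher numbers stand for lower toxicity in this test and lower numbers for higher toxicity in this test), compound 1 (`N#CC1=C(N)OC(c2c[nH]c3ccccc23)=C(C#N)C1c1ccc(Br)cc1`) gives > 100000 nM as a limit of the assay and not a number. Among the measured compounds shown here, compound 2 (`COc1ccc(C2C(C#N)=C(N)OC(c3c[nH]c4ccccc34)=C2C#N)cc1OC`) gives 72100 nM and is so far the only compound with an actual number, so it has no measured number to be ranked against.

Compound 3 (`N#CC1=C(N)OC(c2c[nH]c3ccccc23)=C(C#N)C1c1ccc(F)cc1`) is not yet measured. It carries 4-fluorophenyl in place of 3,4-dimethoxyphenyl on a saturated ring carbon, next to two ring atoms that each bear a cyano group; the counted change is 4-fluorophenyl in place of 3,4-dimethoxyphenyl on a saturated ring carbon in full.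

For the measured compounds named here, one measured step bears on this carbon: an at least 1.3-fold lower number from compound 1 to compound 2 (0.14 log units; that floor lies within the scatter) is the change of 4-bromophenyl for 3,4-dimethoxyphenyl, and its floor does not leave the scatter. That step gives no ground to expect a clear shift in this assay on leaving 3,4-dimethoxyphenyl, so only a slight move to higher numbers, or none, is expected. The estimated move is a 1.2-fold higher number from compound 2 to compound 3 (0.10 log units; within the scatter) and is expected to stay within the scatter. For compound 3 the estimate is 90000 nM with an expected range from 40000 nM to 150000 nM and a real chance of a reading that is only a limit.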

Compound 3, concentration lethal to 50% of the cells: > 100000 nM
Compound 3: only a limit was reported (the forecaster's own chance of this, stated with the estimate: 45%); middle value at least 1.1-fold (0.04 log units) from the limit.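

In this assay, 4-fluorophenyl in place of 3,4-dimethoxyphenyl on the saturated ring carbon gives an at least 1.3-fold higher number from compound 2 to compound 3 (0.14 log units; that floor lies within the scatter), so this step, like the earlier one at this carbon, does not establish a separation beyond the scatter. Compound 3, like compound 1, is reported only as a limit, so neither the 4-fluorophenyl nor the 4-bromophenyl compound has an actual number, and the step between these two cannot be read. The three compounds at this carbon therefore give no ranking of these groups, and the series now has a second reading at the same point:  the limit of > 100000 nM in this assay, at which 2 of the 3 values shown sit.

From the compounds shown here alone, it remains open whether any group on this saturated ring carbon gives a number clearly lower than that of the 3,4-dimethoxyphenyl compound, for example a phenyl ring carrying a dimethylamino group or a carboxylic acid. The 1H-indol-3-yl group and the amino group are the same throughout the compounds shown, so what an acetamide in place of the amino group, or a simple phenyl in place of the 1H-indol-3-yl group, would do in this read-out also remains open.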